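The compounds below may be only part of what the source reports. "The series", "measured", "known", "first", "only" and "open" are said of these compounds alone.

Two compounds have been measured so far:

compound 1, `c1ccc(-c2cn3ccnc3c(-c3ccc4ncn(C5CCCCC5)c4c3)n2)cc1`: 20.7%
compound 2, `CCc1ccc(-c2cn3ccnc3c(-c3ccc4ncn(Cc5ccccc5)c4c3)n2)cc1`: 34.2%

Both values come from a functional assay on COLO 205 cells (Homo sapiens) for inhibition, read by sulforhodamine B assay, with a stated time of 48 h, tested at 10 uM; on this read-out lower numbers stand for less inhibition and higher numbers for more inhibition at the one concentration tested (going by the name of the read-out). Compound 2 stands highest of the two numbers; its nearest neighbour is compound 1, which lies lower by a gap beyond the usual scatter. Among the measured compounds shown here, the two compounds differ at more than one place, so no single step can be drawn between them, and only their two values are known.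

Compound 3, `Cc1cccc(-c2cn3ccnc3c(-c3ccc4ncn(Cc5ccccc5)c4c3)n2)c1`, is not yet measured. It differs from compound 2 in one place: 3-methylphenyl in place of 4-ethylphenyl on an aromatic carbon. For the measured compounds named here, the measured pair gives no step to set against this change, so the expectation rests on the values alone. The step is expected to be small, a number 6.2 percentage points lower from compound 2 to compound 3 (within the scatter), and not clearly beyond the scatter in either direction. Compound 3 is therefore estimated to give 28% in this assay, with a range from 12% to 45%.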

Compound 3, a percentage reported as inhibition, at one concentration (the size of the read-out at that concentration, not a potency): 11.4%
Beside the measured number, compound 3's estimate is 16.6 percentage points above it; measured number below the stated range.
By their numbers in this assay, from the lowest: compounds 3 and 1 (each within the scatter of the next); then compound 2.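

In this assay the group on this aromatic carbon of the shared core clearly counts, since 3-methylphenyl in place of 4-ethylphenyl gives a number 22.8 percentage points lower from compound 2 to compound 3 (beyond the scatter) and so provides the first single-place comparison among these compounds. The swap alters two features together: the chain on the phenyl ring shortens from ethyl to methyl, and that chain moves from the 4-position to the 3-position of the ring. No measurement shown here explains the step.

The compounds shown leave open which of those two features carries the step, a question that 4-methylphenyl or 3-ethylphenyl at this place could separate. They also leave open how the read-out would respond to a different kind of group on this phenyl ring, such as an amine or a carboxylic acid.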